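Swapping cyclobutylamino for isobutoxy on a shared core

The source may hold more compounds than are shown below. What is called first, only, known or untested is meant among the compounds shown, and "the series" means these compounds.

Measured so far in a physicochemical assay for solubility; a lower number here means a less soluble compound, a higher number a more soluble compound:
- compound 1 `C[C@@H]1CN(c2c(C#N)c(C(F)F)nn2-c2ccc(S(C)(=O)=O)cc2)[C@H](C)CO1`: 50 ug/mL
- compound 2 `CS(=O)(=O)c1ccc(-n2nc(C(F)(F)F)cc2NC2CCC2)nc1`: "not determined" (no result reported)
- compound 3 `CS(=O)(=O)c1ccc(-n2nc(C(F)(F)F)c(C#N)c2NC2CCC2)nc1`: "not determined" (no result reported)

Compound 3 has no single number to stand on, and compound 2 is in the same position. For the measured compounds named here, only compound 1 offers a real reading in this assay, so there is no ranking to place compound 3 in, and no measured step between any two compounds to learn from.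

The next compound to be tested is compound 4 `CC(C)COc1c(C#N)c(C(F)(F)F)nn1-c1ccc(S(C)(=O)=O)cn1`. Its structure differs in one place: isobutoxy in place of cyclobutylamino on an aromatic carbon. In words, this is isobutoxy in place of cyclobutylamino on an aromatic carbon.

With no number for compound 3, the size of this step in this assay cannot be read from a starting value. Going by the values given here, the only guide is compound 1 at 50 ug/mL, which carries a different set of groups and is therefore a loose reference. The expectation is a result in the same general region as compound 1, perhaps somewhat lower, and not far beyond the usual scatter. For compound 4 the estimated solubility is 30 ug/mL, with an expected range from 8 ug/mL to 100 ug/mL.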

Compound 4, solubility: < 25 ug/mL
Compound 4 ended at the assay's limit; the forecaster's own chance of this, stated with the estimate: 15%; middle value at least 1.2-fold (0.07 log units) from the limit.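

In this assay compound 4 gives < 25 ug/mL, which is a limit of the assay and not a number. For the compounds shown here, compound 3 has no single number here, and no step from compound 3 to compound 4 can be read. The compounds shown leave open how far isobutoxy in place of cyclobutylamino moves the reading in this assay.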